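Bromo to methyl on the aryl ring of a thiazolylidene hydrazide

The source may hold more compounds than are shown below. What is called first, only, known or untested is meant among the compounds shown, and "the series" means these compounds.

Measured so far:
compound 1 `Cc1ccc(-c2cs/c(=N/NC(=O)CSc3nnnn3-c3ccccc3)n2-c2ccccc2)cc1`, 28.5%
compound 2 `O=C(CSc1ncccn1)N/N=c1/scc(-c2ccc(Br)cc2)n1-c1ccccc1`, 67.6%

Of the compounds shown here, two have been tested in a functional assay on C6 cells (Rattus norvegicus) for cytotoxicity, read by MTT assay, with a stated time of 24 h, tested at 100 ug/mL; a lower number here means a stronger effect, a higher number a weaker effect of the compound at the concentration tested. Compound 1 gives 28.5%, while compound 2 gives 67.6%, the higher of the two numbers and therefore the weaker effect; the gap between compound 2 and compound 1 lies beyond the scatter. The two differ in more than one place, so no single step can be read from them.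

Compound 3 `Cc1ccc(-c2cs/c(=N/NC(=O)CSc3ncccn3)n2-c2ccccc2)cc1` has not yet been measured. It differs from compound 2 by methyl in place of bromo on an aromatic carbon. Among the compounds with values here, no measured pair shows this change on its own, so its effect is open. Compound 3 is expected to give a somewhat lower number than compound 2, with the step of a number 15.6 percentage points lower from compound 2 to compound 3 (beyond the scatter) only a modest one. The estimate for compound 3 is 52%, within 30% to 75%.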

Compound 3, a percentage reported as activity, at one concentration (the size of the read-out at that concentration, not a potency): 45.9%
Estimate against measurement, compound 3: 6.1 percentage points above, and the stated range covers the measured number.
By their numbers in this assay, from the lowest: compound 1; then compound 3; then compound 2.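

In this assay, the change from 4-bromophenyl to 4-methylphenyl, with everything else held constant, gives a number 21.7 percentage points lower from compound 2 to compound 3 (beyond the scatter), showing that the group at this place on the aromatic ring moves the read-out by itself. Compound 3 also isolates a change at the other end of the molecule: with the 4-methylphenyl group kept, pyrimidin-2-yl in place of 1-phenyl-1H-tetrazol-5-yl on the sulfur gives a number 17.4 percentage points higher from compound 1 to compound 3 (beyond the scatter), so both places affect the read-out. Nothing available explains either step.

Going by these compounds, whether the step from bromo to methyl would keep its size and direction with 1-phenyl-1H-tetrazol-5-yl on the sulfur remains open. On these data alone, how an amine or a carboxylic acid at this place on the ring would read also remains open.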